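This account rests on a few compounds, and the source may have more. Where it says the series, first, only, none or still open, it means among the compounds named here.

Going by the values given here, compound 1 `O=C(C1CCCC1)N1CCc2nc(C#Cc3ccccc3)sc2C1` is the one compound here with a measured number: in an assay on HEK293 cells for positive allosteric modulation of metabotropic glutamate receptor 5 (Homo sapiens), read by FLIPR, with a stated time of 1 h (a lower number here means that less compound is needed, a higher number that more compound is needed for the effect), compound 1 gives 19 nM. Compound 2 `CC(C)S(=O)(=O)N1CCc2nc(C#Cc3ccccc3)sc2C1` reaches only the limit > 10000 nM in this assay. Compound 3 `O=S(=O)(C1CC1)N1CCc2nc(C#Cc3ccccc3)sc2C1` likewise reaches only the limit > 10000 nM. The steps of an at least 520-fold higher number from compound 1 to compound 2 (2.72 log units; beyond the scatter) and an at least 520-fold higher number from compound 1 to compound 3 (2.72 log units; beyond the scatter) both replace the carbonyl by a sulfonyl, and both end at the limit of > 10000 nM in this assay, at which 2 of the 3 values shown sit. Compound 4 `O=C(N1CCC(F)CC1)N1CCc2nc(C#Cc3ccccc3)sc2C1` keeps the carbonyl and changes only what sits on it: 4-fluoropiperidin-1-yl in place of cyclopentyl on a carbonyl carbon. The measured steps therefore bear on it only loosely. A modest step upward, within the scatter or a little beyond, is expected from compound 1 to compound 4: a 2.4-fold higher number from compound 1 to compound 4 (0.37 log units; beyond the scatter). Compound 4 is estimated at 45 nM, between 8 nM and 250 nM.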

Compound 4, half-maximal effective concentration: 74 nM
For compound 4 the middle estimate is 1.6-fold (0.22 log units) below the measured one; the range from low to high includes it.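

With the carbonyl kept, cyclopentyl can give way to 4-fluoropiperidin-1-yl, a ring attached through nitrogen, at a modest cost: a 3.9-fold higher number from compound 1 to compound 4 (0.59 log units; beyond the scatter). This position therefore accepts more than one ring on the carbonyl carbon, at least for these two groups. Compound 2 and compound 3, which carry a sulfonyl instead, sit at a limit rather than a number: the limit of > 10000 nM in this assay, at which 2 of the 4 values shown sit.

On these data alone, two things change at once in compound 4, the ring nitrogen and the fluorine, so their separate contributions remain unknown. Plain piperidin-1-yl would separate them, while morpholin-4-yl would test another ring.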